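Methoxy for Chloro in a Thiophene Sulfonamide Series

A few compounds are considered here, and "the series" means these few. Any claim that something is new, unique, unknown or untested is made for them only; others in the source may bear on it.

Of the compounds shown here, three have been tested in a functional assay on HL-60 cells (Homo sapiens) for inhibition, read by CCK-8 assay, with a stated time of 48 h; on this read-out lower numbers stand for stronger inhibition and higher numbers for weaker inhibition. Compound 1 `COc1cccc(NC(=S)NCCNS(=O)(=O)c2ccc(-c3ccccc3Oc3ccc([N+](=O)[O-])cc3)s2)c1` returns only a limit of the assay, > 50000 nM. Compound 2 `O=[N+]([O-])c1ccc(Oc2ccccc2-c2ccc(S(=O)(=O)NCCNC(=S)Nc3cccc(Cl)c3)s2)cc1` likewise returns only a limit, > 50000 nM. Among the measured compounds shown here, compound 3 `O=C(NCCNS(=O)(=O)c1ccc(-c2ccccc2Oc2ccc([N+](=O)[O-])c([N+](=O)[O-])c2)s1)Nc1ccc(Cl)cc1` is the one compound with a number, giving 8100 nM in this assay; how the core of compound 3 differs from that of compound 2 is not broken down here. Compound 1 differs from compound 2 by methoxy in place of chloro on an aromatic carbon, and the resulting step that the two limits leave unreadable from compound 2 to compound 1 cannot be sized because the limit of > 50000 nM in this assay, at which 2 of the 3 values shown sit, covers both compounds.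

Compound 4 `COc1ccc(NC(=O)NCCNS(=O)(=O)c2ccc(-c3ccccc3Oc3ccc([N+](=O)[O-])c([N+](=O)[O-])c3)s2)cc1` has not yet been measured in this assay. It differs from compound 3 by methoxy in place of chloro on an aromatic carbon. This is the same kind of change as that from compound 2 to compound 1, but here the place is para to a large group, whereas there it was meta to a large group. Since the earlier step gives no reading, the expectation rests on compound 3 alone, whose value in this assay is 8100 nM. The step expected is a 1.5-fold higher number from compound 3 to compound 4 (0.17 log units; within the scatter). Compound 4 is therefore estimated at 12000 nM in this assay, with the expected range running from 3500 nM to 50000 nM.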

Compound 4, half-maximal inhibitory concentration: 5400 nM
Beside the measured number, compound 4's estimate is 2.2-fold (0.35 log units) above it; low and high end bracket the measured number.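

In this assay, methoxy in place of chloro on the core of compound 3 gives a 1.5-fold lower number from compound 3 to compound 4 (0.18 log units; within the scatter), so on this core, with the group para to a large group, the two compounds cannot be told apart. The same kind of change on the core of compound 2 gives no readable step, since compound 1 and compound 2 each return only a limit of the assay: the limit of > 50000 nM in this assay, at which 2 of the 4 values shown sit. The series therefore offers a single readable instance of this change, which shows that it is tolerated on the core of compound 3 but does not show that it carries over to the core of compound 2 or to any other core.

The compounds shown leave open how the reading responds when something quite different from methoxy and chloro takes that place on the ring, such as an amine, a carboxylic acid or a longer alkoxy chain. They also leave open whether any such group would move the value of compound 3 beyond the usual scatter.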